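Removing the aminoalkyl chain from the cinnamanilide ether

A few compounds are considered here, and "the series" means these few. Any claim that something is new, unique, unknown or untested is made for them only; others in the source may bear on it.

Compound 2 `COc1cc(/C=C/C(=O)Nc2ccccc2)ccc1OCCCCN1CCCC1` stands highest of the two numbers in a physicochemical assay for lipophilicity, using the shake flask method, measured as octanol-water partition, at pH 7.4 (on this read-out lower numbers stand for lower lipophilicity and higher numbers for higher lipophilicity), giving 1.6, with compound 1 `COc1cc(/C=C/C(=O)Nc2ccccc2)ccc1OCCCCN(C)C` nearest at 1.57. For the measured compounds named here, the only measured step, a number 0.03 log units higher from compound 1 to compound 2 (within the scatter), exchanges one amine for another and does not touch the ether side chain, so it offers no direct guide. Compound 3 `COc1cc(/C=C/C(=O)Nc2ccccc2)ccc1O` differs from compound 2 by hydrogen in place of 4-(pyrrolidin-1-yl)butyl on an oxygen on an aromatic ring, removing the whole nine-heavy-atom chain with its nitrogen. Compound 3 is therefore expected to move well beyond the scatter, by a number 1.40 log units higher from compound 2 to compound 3 (beyond the scatter), to an estimated 3, between 2.3 and 3.7.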

Compound 3, partition coefficient: 1.42
Compound 3: middle estimate off by 1.58 log units, on the high side; the whole stated range lies above it.
By their numbers in this assay, from the lowest: compounds 3, 1 and 2 (each within the scatter of the next).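

In this assay, hydrogen in place of 4-(pyrrolidin-1-yl)butyl on an oxygen on an aromatic ring gives a number 0.18 log units lower from compound 2 to compound 3 (within the scatter), and hydrogen in place of 4-(dimethylamino)butyl at that oxygen gives a number 0.15 log units lower from compound 1 to compound 3 (within the scatter). At this position, then, the whole chain with its nitrogen can go without the number leaving the scatter, whichever of the two amines ends the chain. Nothing available explains this result.

From the compounds shown here alone, it remains open whether a methyl group or a propyl chain on that oxygen would also stay within the scatter. Going by these compounds, it is equally open whether a chain ending in a carboxylic acid would do so.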